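Halogen swap on the phenoxy ring of compound 3

This account rests on a few compounds, and the source may have more. Where it says the series, first, only, none or still open, it means among the compounds named here.

Measured so far:
compound 1 `Cc1nn(C)c(Oc2ccc(F)cc2)c1/C=N\OCc1c(Cl)c(-c2ccc(F)cc2)nn1C` — 8020 nM
compound 2 `Cc1ccc(Oc2c(/C=N\OCc3c(Cl)c(-c4ccc(F)cc4)nn3C)c(C)nn2C)cc1` — 2910 nM
compound 3 `Cc1nn(C)c(Oc2ccc(F)cc2)c1/C=N\OCc1c(Cl)c(-c2ccc(Cl)cc2)nn1C` — 7250 nM

In a functional assay on HCT-116 cells (Homo sapiens) for antiproliferative activity, read by MTT assay, with a stated time of 72 h (a higher number here means a weaker inhibitor, a lower number a stronger inhibitor), compound 3 stands second highest of the three numbers; its gap to compound 1 is within the scatter, while compound 2 gives a number beyond the scatter lower. Compound 4 `Cc1nn(C)c(Oc2ccc(Br)cc2)c1/C=N\OCc1c(Cl)c(-c2ccc(Cl)cc2)nn1C` carries the change (bromo in place of fluoro on an aromatic carbon). Going by the values given here, two steps bear on it: a 2.8-fold lower number from compound 1 to compound 2 (0.44 log units; beyond the scatter) at the same place, and a 1.1-fold lower number from compound 1 to compound 3 (0.04 log units; within the scatter), a halogen exchange on the other aryl ring. A larger group at this place has so far lowered the number modestly, whereas a halogen-for-halogen swap elsewhere changed nothing, so a small downward step is expected, a 1.6-fold lower number from compound 3 to compound 4 (0.21 log units; within the scatter). Compound 4 is estimated at 4500 nM, within 2000 nM to 10000 nM.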

Compound 4, half-maximal inhibitory concentration: 5910 nM
The estimate for compound 4 lay 1.3-fold (0.12 log units) below the measured number; the range from low to high includes it.
By their numbers in this assay, from the lowest: compound 2; then compounds 4, 3 and 1 (each within the scatter of the next).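

In this assay, bromo in place of fluoro at this place gives a 1.2-fold lower number from compound 3 to compound 4 (0.09 log units; within the scatter), so this halogen exchange on the ring bearing the oxygen link leaves the number unchanged within the scatter. Methyl in place of fluoro gave a 2.8-fold lower number from compound 1 to compound 2 (0.44 log units; beyond the scatter), a step beyond the scatter that bromo does not repeat, although that step was read with fluoro rather than chloro on the other aryl ring. Nothing measured here bears on this difference between methyl and bromo.

Going by these compounds, whether methyl keeps its step with chloro on the other aryl ring remains open. So does the effect of an amine or a carboxylic acid at this place.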